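A Fluorinated Benzylamide Variant on the Shared Core

A few compounds are considered here, and "the series" means these few. Any claim that something is new, unique, unknown or untested is made for them only; others in the source may bear on it.

Compound 1 `CCN(Cc1ccccc1)C(=O)c1nn(-c2ccc(F)cc2)c(OC[C@@H](O)C[C@@H](O)CC(=O)O)c1C(C)C` carries a benzyl(ethyl)amino group on a carbonyl carbon of the shared core. In an assay on microsomes from liver for inhibition of 3-hydroxy-3-methylglutaryl-coenzyme A reductase (Rattus norvegicus) (a lower number here means a stronger inhibitor, a higher number a weaker inhibitor), compound 1 gives 14 nM, the highest number among the three measured compounds. Compound 2 `COc1ccc(CNC(=O)c2nn(-c3ccc(F)cc3)c(OC[C@@H](O)C[C@@H](O)CC(=O)O)c2C(C)C)cc1` gives 12 nM, and compound 3 `CC(C)c1c(C(=O)NCc2ccc(Cl)cc2)nn(-c2ccc(F)cc2)c1OC[C@@H](O)C[C@@H](O)CC(=O)O` gives 6.7 nM. The two measured steps leaving compound 1, a 1.2-fold lower number from compound 1 to compound 2 (0.07 log units; within the scatter) and a 2.1-fold lower number from compound 1 to compound 3 (0.32 log units; beyond the scatter), both exchange that amine for a substituted benzylamino group. Compound 4 `CC(C)c1c(C(=O)N(C)Cc2cccc(F)c2)nn(-c2ccc(F)cc2)c1OC[C@@H](O)C[C@@H](O)CC(=O)O` differs from compound 1 in one place: (3-fluorobenzyl)(methyl)amino in place of benzyl(ethyl)amino on a carbonyl carbon. Since both known steps from compound 1 lead to a lower or unchanged number, a step of similar size is expected in this assay, a 1.3-fold lower number from compound 1 to compound 4 (0.10 log units; within the scatter). Compound 4 is therefore estimated at 11 nM, with a range from 5 nM to 25 nM.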

Compound 4, half-maximal inhibitory concentration: 14 nM
Compound 4: the middle estimate sits 1.3-fold (0.10 log units) below what was measured, and the stated range covers the measured number.
By their numbers in this assay, from the lowest: compounds 3, 2, 1 and 4 (each within the scatter of the next, the first and the last beyond it).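

Compound 4 adds a second case in which the amine keeps two carbon groups on its nitrogen, and here no change at the digits printed from compound 1 to compound 4 (within the scatter) in this assay shows that the fluorine and methyl exchange leaves the number in place. Set against the amines with an amide hydrogen, a 1.2-fold higher number from compound 2 to compound 4 (0.07 log units; within the scatter) stays level, whereas a 2.1-fold higher number from compound 3 to compound 4 (0.32 log units; beyond the scatter) separates compound 4 only from the (4-chlorobenzyl)amino compound. No measurement offered here explains these numbers. The compounds shown do not separate the fluorine from the methyl, and they leave open how a piperidine amide would read at this carbonyl carbon.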